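The compounds below may be only part of what the source reports. "The series", "measured", "known", "first", "only" and "open" are said of these compounds alone.

Measured so far in an ADME assay on microsomes from liver (Mus musculus) for metabolic stability, read by LC-MS, using NADPH, with a stated time of 60 min, tested at 1 uM (on this read-out lower numbers stand for a shorter-lived compound and higher numbers for a longer-lived compound), are:
- compound 1 `O=S(=O)(c1cccc(C(F)(F)F)c1)N1CCc2ccc(OCc3c(F)cccc3Cl)cc21` with 0.0483 h
- compound 2 `O=S(=O)(c1cccc(C(F)(F)F)c1)N1CCc2ccc(-c3cc(F)cc(OC(F)F)c3)cc21` with 0.19 h
- compound 3 `O=S(=O)(c1cccc(C(F)(F)F)c1)n1ccc2ccc(-c3cc(F)cc(OC(F)F)c3)cc21` with 0.652 h

Compound 3 at 0.652 h stands highest of the three. Compound 4 `O=C(O)CCc1cc2ccc(-c3cc(F)cc(OC(F)F)c3)cc2n1S(=O)(=O)c1cccc(C(F)(F)F)c1` differs from it by 2-carboxyethyl in place of hydrogen on an aromatic carbon with the new group next to the ring nitrogen. For the measured compounds named here, no measured step touches that place. Going by the values given here, the only measured step, a 3.9-fold higher number from compound 1 to compound 2 (0.59 log units; beyond the scatter), lies at a different place and serves as a gauge of size alone. In this assay a rise of similar or smaller size is therefore expected, with low confidence in its direction. The expected change is a 2.3-fold higher number from compound 3 to compound 4 (0.36 log units; beyond the scatter) and remains an estimate. Compound 4 is estimated at 1.5 h with an expected range from 0.45 h to 5 h on this read-out.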

Compound 4, half-life: > 2.41 h
Compound 4 ended at the assay's limit (the forecaster's own chance of this, stated with the estimate: 25%); at least 1.6-fold (0.20 log units) between middle value and limit.
By their numbers in this assay, from the lowest: compound 1; then compound 2; then compound 3. At a limit, above all of these: compound 4.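

In this assay, 2-carboxyethyl in place of hydrogen on the aromatic carbon next to the ring nitrogen gives an at least 3.6-fold higher number from compound 3 to compound 4 (0.56 log units; beyond the scatter). For the compounds shown here, no earlier compound carries a group at this place, and this one shows that the place takes a chain with a carboxylic acid without any fall in half-life. Compound 4 stands at a limit of the assay, not at a number, so the step gives only a lower bound: the limit of > 2.41 h in this assay, at which 1 of the 4 values shown sits.

The compounds shown leave open whether the rise belongs to the carboxylic acid or to the chain; a methyl ester, an amine or a shorter chain at this place could separate the two. They also leave open how far past the limit compound 4 lies.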